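A few compounds are considered here, and "the series" means these few. Any claim that something is new, unique, unknown or untested is made for them only; others in the source may bear on it.

Compound 1, `C=CCNC(=C\C(=O)/C=C/c1ccc(O)c(OC)c1)/C=C/c1ccc(O)c(OC)c1`, was tested in an ADME assay on Caco-2 cells (Homo sapiens) for inhibition, read by sulforhodamine B assay, with a stated time of 72 h; a lower number here means a stronger inhibitor, a higher number a weaker inhibitor. In this assay compound 1 gives > 25000 nM, which is a limit of the assay rather than a number. Two other compounds built on the same core share that outcome. Compound 2, `COc1cc(/C=C/C(=O)/C=C(/C=C/c2ccc(OC(C)=O)c(OC)c2)NCC(C)C)ccc1OC(C)=O`, gives > 25000 nM in this assay, again a limit. Compound 3, `CCC(C)NC(=C\C(=O)/C=C/c1ccc(O)cc1)/C=C/c1ccc(O)cc1`, gives > 25000 nM in this assay, also a limit. So compound 1 stands exactly where every measured compound here stands, all of them sitting at the limit of > 25000 nM in this assay, at which 3 of the 3 values shown sit; none of them has a number that could be ordered against another.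

Compound 4, `CCCCNC(=C\C(=O)/C=C/c1ccc(O)c(OC)c1)/C=C/c1ccc(O)c(OC)c1`, has not yet been measured in this assay. It differs from compound 1 in one place: propyl in place of vinyl on a saturated chain carbon bound to an amine nitrogen. The group on the amine nitrogen grows from allyl to butyl and loses its one double bond outside aromatic rings; everything else in the molecule stays as it is.

Going by the values given here, no measured pair in this set differs in one place, so no measured step can guide the size of this change. Among the compounds with values here, with every value so far at the limit, the expected step that the limit leaves unreadable from compound 1 to compound 4 is none beyond the scatter. Compound 4 is therefore expected to give about 35000 nM, most likely once more only a limit, within a range from 15000 nM to 80000 nM.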

Compound 4, half-maximal inhibitory concentration: > 25000 nM
Compound 4 ended at the assay's limit; the forecaster's own chance of this, stated with the estimate: 85%; the middle value does not contradict the limit.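

In this assay compound 4 gives > 25000 nM, which is a limit of the assay and not a number. Going by these compounds alone, compound 1 also has only a limit, so no step between compound 1 and compound 4 can be read. All compounds shown stand at the same point: the limit of > 25000 nM in this assay, at which 4 of the 4 values shown sit.

The compounds shown leave open whether allyl or butyl on the amine nitrogen makes any difference to inhibition, and how strong an inhibitor any of them is.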